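The source may hold more compounds than are shown below. What is called first, only, known or untested is meant among the compounds shown, and "the series" means these compounds.

Measured compounds in this series:

compound 1 `Brc1cn2ccnc2c(-c2ccc3ncn(C4CCCCC4)c3c2)n1` gives 10% in a functional assay on 786-0 cells (Homo sapiens) for inhibition, read by sulforhodamine B assay, with a stated time of 48 h, tested at 10 uM; on this read-out higher numbers stand for more inhibition at the one concentration tested (going by the name of the read-out) and lower numbers for less inhibition
compound 2 `c1ccc(-c2cn3ccnc3c(-c3ccc4ncn(C5CCCCC5)c4c3)n2)cc1` gives 36.8% in this assay
compound 3 `c1cn2cc(-c3ccsc3)nc(-c3ccc4ncn(C5CCCCC5)c4c3)c2n1` gives 6.35%

Compound 1 stands second highest of the three numbers in this assay. Its nearest neighbour is compound 3, a gap that lies within the usual scatter, so the two cannot be ordered; its furthest is compound 2, which lies beyond the scatter.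

The step under consideration is from compound 1 to compound 4 `Clc1ccc(-c2cn3ccnc3c(-c3ccc4ncn(C5CCCCC5)c4c3)n2)cc1`, a change of 4-chlorophenyl in place of bromo on an aromatic carbon.

Within the data shown here, two measured steps bear on it. The closest is a number 26.8 percentage points higher from compound 1 to compound 2 (beyond the scatter), where a six-membered carbon ring enters at the same position. The 4-chlorophenyl group of compound 4 differs from that phenyl only by its chlorine, so a comparable step is the natural reference. Against a general gain from any ring at this position stand a number 3.7 percentage points lower from compound 1 to compound 3 (within the scatter) and a number 30.5 percentage points lower from compound 2 to compound 3 (beyond the scatter): the thiophen-3-yl analogue did not share the gain seen with phenyl. The expectation is therefore an upward step in this assay of roughly the size of a number 26.8 percentage points higher from compound 1 to compound 2 (beyond the scatter), with the thiophene result as a reason to keep the range wide on the low side.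

Compound 4 is estimated at 32% in this assay, with a range from 10% to 55%, which means an expected step of a number 22 percentage points higher from compound 1 to compound 4 (beyond the scatter).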

Compound 4, a percentage reported as inhibition, at one concentration (the size of the read-out at that concentration, not a potency): 12.1%
Compound 4: the middle estimate sits 19.9 percentage points above what was measured, and the stated range covers the measured number.
By their numbers in this assay, from the lowest: compounds 3, 1 and 4 (each within the scatter of the next); then compound 2.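

In this assay, the gain seen with phenyl does not carry over to its chlorinated analogue: chloro in place of hydrogen on that aromatic ring gives a number 24.7 percentage points lower from compound 2 to compound 4 (beyond the scatter), a step beyond the scatter. A six-membered aromatic carbon ring in place of bromo is therefore not enough by itself to give a gain, as a number 2.1 percentage points higher from compound 1 to compound 4 (within the scatter) and a number 5.8 percentage points higher from compound 3 to compound 4 (within the scatter) both lie within the scatter, leaving the bromo, thiophen-3-yl and 4-chlorophenyl compounds unordered, with only compound 2 standing apart from the other three. Nothing available accounts for the drop that comes with the single chlorine.

Open, going by these compounds, is whether the phenyl gain is lost with any group on that ring or only with chloro, for example whether a methoxy group, an amine or a carboxylic acid in place of the chlorine would behave like compound 2 or like compound 4. Also open, on these data alone, is whether the gap between compound 2 and the other three reflects a difference in potency, as each number comes from one concentration and the rest of the core stays the same throughout.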